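The compounds below may be only part of what the source reports. "The series", "measured", "known", "first", "only" and "open" are said of these compounds alone.

Of the compounds shown here, three have numbers so far in a physicochemical assay for solubility, at pH 7.2 (a lower number here means a less soluble compound, a higher number a more soluble compound), and compound 3 (`COc1c(/C=C/c2ccc(NS(C)(=O)=O)cc2)cc(N2CCC(=O)NC2=O)cc1C(C)(C)C`) reads 10300 nM there. That places it within the scatter of compound 2 (`COc1c(/C=C/c2ccc(NS(C)(=O)=O)c(F)c2)cc(-n2ccc(=O)[nH]c2=O)cc1C(C)(C)C`) at 15500 nM while compound 1 (`COc1c(CNc2ccc(NS(C)(=O)=O)cc2)cc(N2CCC(=O)NC2=O)cc1C(C)(C)C`) at 90800 nM lies beyond the scatter from compound 3, on the more soluble side.

The change to compound 4 (`COc1c(/C=C/c2ccc(NS(C)(=O)=O)cc2)cc(-n2ccc(=O)[nH]c2=O)cc1C(C)(C)C`) is a group of 8 heavy atoms (4 carbon, 2 nitrogen, 2 oxygen; one six-membered aromatic ring with 2 hetero atoms) in place of a group of 8 heavy atoms (4 carbon, 2 nitrogen, 2 oxygen; one six-membered non-aromatic ring with 2 hetero atoms), on an aromatic carbon and it sits para to a methoxy group and meta to a tert-butyl group. Within the data shown here, no measured pair isolates this change. Among the measured compounds shown here, the group that enters also stands in compound 2, which gives 15500 nM and so lies within the scatter of compound 3 at 10300 nM in this assay and this is the only guide to hand. No step beyond the scatter is therefore expected. The estimated step of a 1.2-fold higher number from compound 3 to compound 4 (0.07 log units; within the scatter) is expected to remain small, with no firm direction. Compound 4 is estimated at 12000 nM within an expected range of 5000 nM to 28000 nM when it is measured.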

Compound 4, solubility: 20700 nM
The estimate for compound 4 lay 1.7-fold (0.24 log units) below the measured number; measured number inside the range.
By their numbers in this assay, from the lowest: compounds 3, 2 and 4 (each within the scatter of the next); then compound 1.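

In this assay, among these compounds, the first pair to isolate this position places a six-membered aromatic ring with 2 hetero atoms in place of a six-membered non-aromatic ring with 2 hetero atoms, para to a methoxy group, and it gives a 2.0-fold higher number from compound 3 to compound 4 (0.30 log units; within the scatter), so the two rings are not told apart here. Hydrogen in place of fluoro on an aromatic carbon gives a 1.3-fold higher number from compound 2 to compound 4 (0.13 log units; within the scatter), which also leaves that pair inside the scatter. Nothing at hand offers an explanation for either step.

The compounds shown leave open whether a different group at this position, such as an amine or a carboxylic acid, would read apart from these two rings in this assay. They also leave open whether the same exchange of rings would read alike in the core of compound 1 .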